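The compounds below may be only part of what the source reports. "The series", "measured", "known", "first", "only" and "open" are said of these compounds alone.

In an ADME assay on HaCaT cells (Homo sapiens) for cytotoxicity, read by MTT assay, with a stated time of 48 h (on this read-out higher numbers stand for weaker inhibition and lower numbers for stronger inhibition), compound 3 (`COc1ccc(-c2nn(-c3ccccc3)cc2-c2nc3cc(C)ccc3[nH]2)cc1`) gives > 50000 nM, which is a limit and not a number. Compound 2 (`Cc1cc2nc(-c3cn(-c4ccccc4)nc3-c3ccc(Cl)cc3)[nH]c2cc1C`) gives > 50000 nM, also a limit. Among the compounds with values here, no compound in this set has yet given a number: the limit of > 50000 nM in this assay, at which 3 of the 3 values shown sit.

Compound 4 (`COc1ccc(-c2nn(-c3ccccc3)cc2-c2nc3cc(C)c(C)cc3[nH]2)cc1`) differs from compound 3 in one place: methyl in place of hydrogen on an aromatic carbon. The methyl enters on an aromatic carbon of the six-membered ring of carbon only, ortho to a methyl group. Within the data shown here, no measured step covers this change. Among the measured compounds shown here, the only measured step, a step that the two limits leave unreadable from compound 1 to compound 2, is a different change, chloro in place of hydrogen on an aromatic carbon, and its size cannot be read. Compound 1 (`Cc1cc2nc(-c3cn(-c4ccccc4)nc3-c3ccccc3)[nH]c2cc1C`) carries the same two methyl groups as compound 4 but no methoxy group. Compound 1 gives > 50000 nM, again a limit.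

With all three values at the limit, the data give no ground for expecting a move in either direction, and the expected change stays within the scatter. The expected step is a number no higher from compound 3 to compound 4 (the limit leaves the size open). Compound 4 is expected to read near 50000 nM, and most likely to be reported only as a limit. The estimated range for compound 4 runs from 30000 nM to 100000 nM.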

Compound 4, half-maximal inhibitory concentration: 21400 nM
Beside the measured number, compound 4's estimate is 2.3-fold (0.37 log units) above it, outside the stated range (below it).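

Methyl on this aromatic carbon, ortho to a methyl group, is the first change in the series to bring a reading off the limit in this assay, with an at least 2.3-fold lower number from compound 3 to compound 4 (0.36 log units; beyond the scatter). The methoxy group matters as well, with an at least 2.3-fold lower number from compound 2 to compound 4 (0.36 log units; beyond the scatter) for methoxy in place of chloro and an at least 2.3-fold lower number from compound 1 to compound 4 (0.36 log units; beyond the scatter) for methoxy in place of hydrogen, so among these four compounds a number appears only where the methoxy group and the two methyl groups occur together. All the other compounds remain at a limit and not at a number: the limit of > 50000 nM in this assay, at which 3 of the 4 values shown sit.

On these data alone, the three new steps are bounds that start from a limit, so their true sizes stay open, and the step with chloro in place of hydrogen cannot be read. Also open, as far as these compounds go, is whether a longer chain such as ethyl, or an amine, on the same aromatic carbon would give a number at all, and whether that number would lie lower still than that of compound 4 at 21400 nM.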